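Chain variation on a shared bicyclic triazole scaffold

The source may report more compounds than this note shows. Statements on the series, on what has been measured and on what is new or still open speak of the compounds shown alone.

Measured so far:
compound 1 `CCSCCC12CCC(c3nnc(-c4ccccc4C(F)(F)F)n3C)(CC1)CC2` — an assay on CHO-K1 cells for inhibition of 11-beta-hydroxysteroid dehydrogenase type 2 (Mus musculus), read by scintillation proximity assay; on this read-out higher numbers stand for weaker inhibition and lower numbers for stronger inhibition: > 4000 nM, a limit
compound 2 `Cn1c(-c2ccccc2C(F)(F)F)nnc1C12CCC(CCS(=O)(=O)C(C)(C)C)(CC1)CC2` — this assay: > 4000 nM, a limit
compound 3 `CCS(=O)(=O)CCC12CCC(c3nnc(-c4ccccc4Br)n3C)(CC1)CC2` — this assay: > 4000 nM, a limit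

Compound 2 stands only at a limit in this assay. Within the data shown here, all three measured values sit at the limit of > 4000 nM in this assay, at which 3 of the 3 values shown sit, so no compound can be ordered against another. Among the measured compounds shown here, the one single-point step, a step that the two limits leave unreadable from compound 1 to compound 2, is unreadable between two limits.

Compound 4 `CC(O)CCCC12CCC(c3nnc(-c4ccccc4C(F)(F)F)n3C)(CC1)CC2` differs from compound 2 by 2-hydroxypropyl in place of (tert-butyl)sulfonyl on a saturated chain carbon, two bonds along the chain from a saturated ring carbon. For the measured compounds named here, no measured step with a readable size bears on this change; the evidence is limits only. The step that the limit leaves unreadable from compound 2 to compound 4 is therefore expected to be unreadable as well, with compound 4 most likely again reported as a limit. Compound 4 is estimated at 6000 nM, within 2000 nM to 20000 nM.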

Compound 4, half-maximal inhibitory concentration: > 4000 nM
Compound 4 was reported as a limit; the forecaster's own chance of this, stated with the estimate: 80%; the middle value does not contradict the limit.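

No new step can be read from compound 4 to compound 1 or compound 2, as each stands only at a limit: the limit of > 4000 nM in this assay, at which 4 of the 4 values shown sit. The compounds shown leave open whether any chain on the shared core gives a numeric value in this assay.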